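This account rests on a few compounds, and the source may have more. Where it says the series, first, only, none or still open, it means among the compounds named here.

Measured compounds:
Compound 1, `O=S(=O)(/C=C/c1ccc(F)cc1F)Cc1ccc(Nc2ncnc3ccccc23)cc1`: > 100000 nM in a functional assay on HT-29 cells (Homo sapiens) (a lower number here means a stronger inhibitor of growth, a higher number a weaker inhibitor of growth), a limit of the assay rather than a number.
Compound 2, `O=S(=O)(/C=C/c1ccc(F)cc1Cl)Cc1ccc(Nc2ncnc3ccccc23)cc1`: 100000 nM in this assay.
Compound 3, `O=S(=O)(/C=C/c1ccc(F)cc1Cl)Cc1ccc(Nc2ncnc3cc(Cl)ccc23)cc1`: > 100000 nM in this assay, again a limit of the assay rather than a number.

All three compounds share one core, and none of them slows the growth of these cells to a measurable degree within the tested range. Compound 1 differs from compound 2 in one place only: fluoro in place of chloro on an aromatic carbon. The step this makes is a number no lower from compound 2 to compound 1 (the limit leaves the size open); its size cannot be read because of the limit of > 100000 nM in this assay, at which 2 of the 3 values shown sit. Compound 3 differs from compound 2 in one place as well: chloro in place of hydrogen on an aromatic carbon. The step here is a number no lower from compound 2 to compound 3 (the limit leaves the size open), and its size is likewise not readable because of the limit of > 100000 nM in this assay, at which 2 of the 3 values shown sit.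

Compound 4, `O=S(=O)(/C=C/c1ccc(F)cc1F)Cc1ccc(Nc2ncnc3cc(Cl)ccc23)cc1`, has not yet been measured. It differs from compound 3 by the same kind of change that turns compound 2 into compound 1: fluoro in place of chloro on an aromatic carbon. The two places are described in the same words, so the change is the same; the two cores differ only by chloro in place of hydrogen on an aromatic carbon. Since compound 3 gives > 100000 nM, a limit, and compound 1 after the same change also gives > 100000 nM, a limit, compound 4 is expected to remain without measurable effect, an expected step of a number no higher from compound 3 to compound 4 (the limit leaves the size open). The estimate for compound 4 in this assay is therefore 100000 nM, expected between 50000 nM and 200000 nM, most likely reported only as a limit.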

Compound 4, concentration for 50% growth inhibition: > 100000 nM
Compound 4: no number, only a limit (the forecaster's own chance of this, stated with the estimate: 75%); the middle value sits exactly at the limit.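

The steps from compound 3 to compound 4 and from compound 1 to compound 4 cannot be read, because both compounds in each pair stand at a limit rather than a number: the limit of > 100000 nM in this assay, at which 3 of the 4 values shown sit. The compounds shown leave open whether fluoro in place of chloro, or chloro in place of hydrogen, changes growth inhibition at all in this assay.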